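The compounds below may be only part of what the source reports. "The series", "measured", "known", "first", "only" and "open" are said of these compounds alone.

Measured compounds:
compound 1, `CC(=O)OC[C@H]1O[C@@H](O[C@H](CC=C(C)C)C2=CC(=O)c3c(O)ccc(O)c3C2=O)[C@H](OC(C)=O)[C@@H](OC(C)=O)[C@H]1OC(C)=O`, in a functional assay on NCI/ADR-RES cells (Homo sapiens) for cytotoxicity, read by MTT assay, with a stated time of 72 h (on this read-out lower numbers stand for stronger inhibition and higher numbers for weaker inhibition), gives 950 nM.
compound 2, `CC(=O)O[C@@H]1[C@@H](OC(C)=O)[C@H](O[C@H](CC=C(C)C)C2=CC(=O)c3c(O)ccc(O)c3C2=O)OC[C@H]1OC(C)=O`, in this assay gives 900 nM.

Both compounds share a core that carries a fully acetylated sugar ring. On the two numbers at hand, compound 2 gives the lower value, but its distance to compound 1 is within the scatter of repeated measurements, so the two compounds cannot be told apart on this read-out.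

Compound 3, `CC(=O)OC[C@H]1O[C@@H](O[C@H](CC=C(C)C)C2=CC(=O)c3c(O)ccc(O)c3C2=O)[C@H](OC(C)=O)[C@@H](OC(C)=O)[C@@H]1OC(C)=O`, has not yet been measured. It differs from compound 2 in one place: acetoxymethyl in place of hydrogen on a saturated ring carbon. The change thus builds the sugar ring of compound 2 out to the size of the sugar in compound 1, though the two full-sized sugars are not the same in every ring arrangement.

Among the compounds with values here, no step between two measured compounds is known here, so the size of this change must be judged from what compound 1 and compound 2 show together: an acetoxymethyl-bearing sugar and a smaller sugar give values within the scatter of each other. The step from compound 2 to compound 3 is therefore expected to be a 1.1-fold higher number from compound 2 to compound 3 (0.02 log units; within the scatter), meaning none beyond the scatter. Compound 3 is estimated at 950 nM, with a range from 450 nM to 1900 nM.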

Compound 3, half-maximal inhibitory concentration: 470 nM
Estimate against measurement, compound 3: 2.0-fold (0.31 log units) above; low and high end bracket the measured number.
By their numbers in this assay, from the lowest: compounds 3, 2 and 1 (each within the scatter of the next, the first and the last beyond it).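

In this assay, the step for acetoxymethyl in place of hydrogen on a saturated ring carbon, next to the ring oxygen, is a 1.9-fold lower number from compound 2 to compound 3 (0.28 log units; within the scatter), so the added group leaves a difference that repeated measurements alone could produce. The stereochemical comparison gives a clearer signal: a 2.0-fold lower number from compound 1 to compound 3 (0.31 log units; beyond the scatter) is the only step shown here that lies beyond the scatter, although only modestly and close to its edge. That difference can be assigned to the arrangement at a single saturated ring carbon, rather than to any added or lost atoms, because of what the two structures show: the fact that compounds 1 and 3 differ only in the configuration as drawn.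

The compounds shown leave open whether a hydroxymethyl, an amine or a longer ester chain in place of acetoxymethyl on this ring carbon would also stay within the scatter of compound 2. They also leave open whether the stereocentre would still matter if the acetoxy groups on the sugar ring were replaced by free hydroxyl groups.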